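A few compounds are considered here, and "the series" means these few. Any claim that something is new, unique, unknown or untested is made for them only; others in the source may bear on it.

Working notes on the series.

Of the compounds shown here, two have numbers so far in a functional assay on HepG2 cells (Homo sapiens) for antiproliferative activity, read by MTT assay, with a stated time of 48 h; on this read-out lower numbers stand for stronger inhibition and higher numbers for weaker inhibition. Compound 1 `CCOC(=O)CN(Cc1ccccc1)c1nc(NCc2ccccc2)ncc1[N+](=O)[O-]` gives 21000 nM in this assay. Compound 2 `CCOC(=O)CNc1ncc([N+](=O)[O-])c(N(CC(=O)OCC)Cc2ccccc2)n1` gives 44500 nM in this assay. Between the two lies a single structural change, and it comes with a step of a 2.1-fold higher number from compound 1 to compound 2 (0.33 log units; beyond the scatter). On the numbers shown, compound 2 stands highest of the two, with compound 1 as its nearest neighbour at a lower number, that gap being beyond the scatter.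

Compound 3 `CCOC(=O)CN(Cc1ccccc1)c1nc(Nc2ccc(Cl)cc2)ncc1[N+](=O)[O-]` is the next member to be measured. It differs from compound 2 in one place: 4-chlorophenyl in place of (ethoxycarbonyl)methyl on a nitrogen on an aromatic ring. Within the data shown here, no measured step touches this nitrogen; the only step in hand, from compound 1 to compound 2, concerns the other nitrogen on the core and is modest in size. Among the measured compounds shown here, the bearing of that step on the present change is therefore indirect, and it shows only that a swap of this kind can move the number by a modest amount in either direction.

For the measured compounds named here, the expectation for compound 3 is a change of a 2.0-fold lower number from compound 2 to compound 3 (0.31 log units; beyond the scatter) relative to compound 2, an estimate that rests on the scale of the single step seen so far. Compound 3 is therefore expected to give about 22000 nM in this assay, with a range from 8000 nM to 60000 nM.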

Compound 3, half-maximal inhibitory concentration: 30900 nM
The estimate for compound 3 lay 1.4-fold (0.15 log units) below the measured number, and the stated range covers the measured number.
By their numbers in this assay, from the lowest: compounds 1, 3 and 2 (each within the scatter of the next, the first and the last beyond it).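

On this nitrogen on an aromatic ring, 4-chlorophenyl and (ethoxycarbonyl)methyl are not told apart in this assay, with a 1.4-fold lower number from compound 2 to compound 3 (0.16 log units; within the scatter). The same holds for 4-chlorophenyl and benzyl at this place, with a 1.5-fold higher number from compound 1 to compound 3 (0.17 log units; within the scatter), so compound 3 lies within the scatter of both neighbours, although the benzyl and (ethoxycarbonyl)methyl pair remains separated by a 2.1-fold higher number from compound 1 to compound 2 (0.33 log units; beyond the scatter). An aromatic ring bound directly to this nitrogen is thus tolerated here to the extent these three compounds can show, and no measurement is at hand that would account for this reading.

As far as these compounds go, whether the chlorine contributes anything stays open, since a plain phenyl or a 4-methoxyphenyl on this nitrogen would be needed to separate it from the ring that carries it. Also open, from the compounds shown here alone, is whether a group of a different kind at this place, such as a carboxylic acid in place of the ethyl ester or a basic amine on a longer chain, would move the number beyond the scatter in either direction, given that all three compounds remain weak in this read-out.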